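Swapping the ring on the sulfur-linked arm

The compounds below may be only part of what the source reports. "The series", "measured", "known", "first", "only" and "open" are said of these compounds alone.

Compound 1 `N#Cc1c(N)nc(SCC(=O)NCO)c(C#N)c1-c1ccc(OCC2CC2)cc1`: 8%
Compound 2 `CNC(=O)CSc1nc(N)c(C#N)c(-c2ccc(OCC3CC3)cc2)c1C#N`: 3%
Compound 3 `N#Cc1c(N)nc(SCc2cnc[nH]2)c(C#N)c1-c1ccc(OCC2CC2)cc1`: 1%

In an assay on CHO cells for displacement of a labelled ligand from adenosine receptor A3 (Homo sapiens), read by scintillation counting, with a stated time of 120 min, tested at 1 uM (on this read-out lower numbers stand for less inhibition and higher numbers for more inhibition at the one concentration tested (going by the name of the read-out)), compound 3 shows the lowest of the three numbers, but the steps reaching it, a number 2 percentage points lower from compound 2 to compound 3 (within the scatter) and a number 7 percentage points lower from compound 1 to compound 3 (within the scatter), both stay within the scatter, as does a number 5 percentage points lower from compound 1 to compound 2 (within the scatter). Compound 4 `N#Cc1c(N)nc(SCc2csc(N)n2)c(C#N)c1-c1ccc(OCC2CC2)cc1` differs from compound 3 in one place: 2-amino-1,3-thiazol-4-yl in place of 1H-imidazol-5-yl on a saturated chain carbon bound to a sulfur. For the measured compounds named here, no measured step exchanges one ring for another, so the closest guides are the two changes on the same chain carbon bound to a sulfur, a number 7 percentage points lower from compound 1 to compound 3 (within the scatter) and a number 2 percentage points lower from compound 2 to compound 3 (within the scatter), both small. All three compounds sit low in this assay, so compound 4 is expected to stay there, with no step beyond the scatter. Compound 4 is estimated at 5%, between -5% and 20%, an expected step of a number 4 percentage points higher from compound 3 to compound 4 (within the scatter).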

Compound 4, a percentage reported as inhibition, at one concentration (the size of the read-out at that concentration, not a potency): 1%
Compound 4: middle estimate off by 4 percentage points, on the high side; measured number inside the range.
By their numbers in this assay, from the lowest: compounds 3, 4, 2 and 1 (each within the scatter of the next).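

In this assay, exchanging one ring for another on a saturated chain carbon bound to a sulfur gives no change at the digits printed from compound 3 to compound 4 (within the scatter), even though 2-amino-1,3-thiazol-4-yl is larger than 1H-imidazol-5-yl and carries more hydrogen-bond acceptors. The amide arms compare with this ring as a number 2 percentage points lower from compound 2 to compound 4 (within the scatter) and a number 7 percentage points lower from compound 1 to compound 4 (within the scatter), so both rings and both amides read alike here. Nothing available explains these low numbers. As far as these compounds go, whether a carboxylic acid, a primary amine or a longer chain at this position would raise the number remains open.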